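Estimating Compound 4 from Its Nearest Measured Neighbours

This account rests on a few compounds, and the source may have more. Where it says the series, first, only, none or still open, it means among the compounds named here.

Compound 1 `CC(O)(CSc1ccc(Br)cc1)c1nc(-c2ccccc2)no1`, in a functional assay on DU-145 cells (Homo sapiens) for cytotoxicity, read by MTT assay (on this read-out higher numbers stand for weaker inhibition and lower numbers for stronger inhibition), a limit of the assay: > 100000 nM
Compound 2 `CC(O)(CSc1ccc(Cl)cc1)c1nc(-c2ccc(F)c(Cl)c2)no1`, in this assay: 500 nM
Compound 3 `CC(O)(CSc1ccc(Br)cc1)c1nc(-c2ccc(Cl)cc2)no1`, in this assay: 6500 nM

Among the two numbers shown, compound 3 stands highest in this assay, with compound 2 well below it. The value of compound 1 is only a limit (the limit of > 100000 nM in this assay, at which 1 of the 3 values shown sits).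

Compound 4 `CC(O)(CSc1ccc(Br)cc1)c1nc(-c2ccc(F)c(Cl)c2)no1` differs from compound 3 by 3-chloro-4-fluorophenyl in place of 4-chlorophenyl on an aromatic carbon. Within the data shown here, no measured step covers this exact change. Among the measured compounds shown here, the one single-place step, an at least 15-fold lower number from compound 1 to compound 3 (1.18 log units; beyond the scatter), shows that a halogen on that phenyl ring moved the number a great deal, and compound 2, which bears the same 3-chloro-4-fluorophenyl, gives 500 nM in this assay. A step to a lower number is therefore expected, a 7.2-fold lower number from compound 3 to compound 4 (0.86 log units; beyond the scatter). Compound 4 is estimated at 900 nM, between 200 nM and 4000 nM.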

Compound 4, half-maximal inhibitory concentration: 8800 nM
Beside the measured number, compound 4's estimate is 9.8-fold (0.99 log units) below it; measured number outside the range, above it.
By their numbers in this assay, from the lowest: compound 2; then compounds 3 and 4 (each within the scatter of the next). At a limit, above all of these: compound 1.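

In this assay, 3-chloro-4-fluorophenyl at this position stands well apart from plain phenyl, with an at least 11-fold lower number from compound 1 to compound 4 (1.05 log units; beyond the scatter), yet it cannot be told apart from 4-chlorophenyl, with a 1.4-fold higher number from compound 3 to compound 4 (0.13 log units; within the scatter). The low number of compound 2 does not carry over, since bromo in place of chloro elsewhere in the molecule gives an 18-fold higher number from compound 2 to compound 4 (1.25 log units; beyond the scatter). Compound 1 stands only at a limit: the limit of > 100000 nM in this assay, at which 1 of the 4 values shown sits.

On these data alone, how an amine or a carboxylic acid on this phenyl would read remains open. So does whether the gap between chloro and bromo recurs with 4-chlorophenyl at this position.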